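The compounds below may be only part of what the source reports. "The series", "measured", "known", "first", "only" and "open" are said of these compounds alone.

Values from a functional assay on M21 cells (Homo sapiens) for inhibition, read by sulforhodamine B assay, with a stated time of 48 h (on this read-out lower numbers stand for stronger inhibition of growth and higher numbers for weaker inhibition of growth), for the measured compounds:
compound 1 `c1cc(C2CCCCC2)ccc1NC1=NCCO1` gives 17800 nM
compound 2 `CC(C)(C)c1ccc(NC2=NCCO2)cc1` gives 2400 nM
compound 3 `O=C(CCl)NC(=O)Nc1ccc(-c2ccccc2)cc1` gives 1400 nM

Compound 3 and compound 2 lie within the scatter of each other, and compound 1 has the highest number of the three. Compound 4 `CC(C)(C)c1ccc(NC(=O)NC(=O)CCl)cc1` is compound 3 with tert-butyl in place of phenyl on an aromatic carbon and the rest unchanged. Among the compounds with values here, the one measured step with tert-butyl entering is a 7.4-fold lower number from compound 1 to compound 2 (0.87 log units; beyond the scatter) and there cyclohexyl leaves, not phenyl, on a core that differs from that of compound 3. Within the data shown here, that step therefore bears on this change only weakly, and no measured step has phenyl leaving. Its size is not carried over, and in this assay no change beyond the scatter is expected, in either direction. The expected step is a 1.1-fold higher number from compound 3 to compound 4 (0.03 log units; within the scatter) and this estimate has wide margins. For compound 4 the estimated value is 1500 nM within an expected range of 500 nM to 4500 nM.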

Compound 4, concentration for 50% growth inhibition: 1100 nM
Compound 4: middle estimate off by 1.4-fold (0.13 log units), on the high side; the range from low to high includes it.
By their numbers in this assay, from the lowest: compounds 4, 3 and 2 (each within the scatter of the next, the first and the last beyond it); then compound 1.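

In this assay, tert-butyl in place of phenyl on an aromatic carbon, para to a group of 8 heavy atoms, gives a 1.3-fold lower number from compound 3 to compound 4 (0.10 log units; within the scatter) and so leaves the read-out unchanged within the scatter. On the core shared by this pair, the six-membered aromatic ring at this position is therefore not required for growth inhibition at this level: a group with no ring and fewer heavy atoms serves equally in this assay. No separate measurement is available that could account for this equivalence.

Going by these compounds, whether this position also accepts an amine, a carboxylic acid or a longer alkyl chain remains open. On these data alone, it is equally open how phenyl would behave on the core of compound 2, where only tert-butyl and cyclohexyl are represented.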